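A few compounds are considered here, and "the series" means these few. Any claim that something is new, unique, unknown or untested is made for them only; others in the source may bear on it.

Working notes on the series. Three compounds share one core and differ at the sulfonyl sulfur. Compound 1 `CCn1c(=O)c2nc(-c3ccc(S(=O)(=O)N4CCOCC4)cc3)[nH]c2n(CC)c1=O` gives 310 nM in an assay for binding affinity to adenosine receptor A1 (Rattus norvegicus), read by radioligand binding; on this read-out higher numbers stand for weaker inhibition and lower numbers for stronger inhibition. Compound 2 `CCCn1c(=O)c2nc(-c3ccc(S(=O)(=O)NCCCC(=O)OCC)cc3)[nH]c2n(CCC)c1=O`, which differs from the others elsewhere as well as at the sulfonyl sulfur, gives 18.5 nM. Compound 3 `CCn1c(=O)c2nc(-c3ccc(S(=O)(=O)N4CCSCC4)cc3)[nH]c2n(CC)c1=O` gives 646 nM, the highest of the three numbers; its nearest neighbour is compound 1 and its furthest is compound 2. Going by the values given here, the one single-point step measured so far, a 2.1-fold higher number from compound 1 to compound 3 (0.32 log units; beyond the scatter), is modest.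

Compound 4 `CCn1c(=O)c2nc(-c3ccc(S(=O)(=O)NCCCN(C)C)cc3)[nH]c2n(CC)c1=O` is not yet measured. Its change from compound 3 reads ((3-(dimethylamino)propyl)amino in place of thiomorpholin-4-yl on a sulfonyl sulfur). The step from compound 1 to compound 3 bears on it only loosely, since both of those keep a ring on the sulfonyl sulfur, while compound 4 opens it to a chain carrying a hydrogen-bond donor. Among the compounds with values here, compound 2 is the only measured compound with an open chain at that position, and its number is far below that of compound 3, but no single step links it to compound 3. On that basis a lower number is expected for compound 4, with an estimated step of a 4.3-fold lower number from compound 3 to compound 4 (0.63 log units; beyond the scatter). The estimate for compound 4 in this assay is 150 nM, within 40 nM to 600 nM.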

Compound 4, half-maximal inhibitory concentration: 70 nM
The estimate for compound 4 lay 2.1-fold (0.33 log units) above the measured number; low and high end bracket the measured number.
By their numbers in this assay, from the lowest: compound 2; then compound 4; then compound 1; then compound 3.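

In this assay, replacing either ring on the sulfonyl sulfur with the open (3-(dimethylamino)propyl)amino chain lowers the number, with a 9.2-fold lower number from compound 3 to compound 4 (0.97 log units; beyond the scatter) and a 4.4-fold lower number from compound 1 to compound 4 (0.65 log units; beyond the scatter). This position therefore responds to a change from ring to open chain, whereas the earlier 2.1-fold higher number from compound 1 to compound 3 (0.32 log units; beyond the scatter) covered only an exchange of one ring for another. No measurement bears on why the open chain gives the lower number.

The change removes the ring and adds a hydrogen-bond donor and a dimethylamino end all at once, so the compounds shown do not separate these features. A plain propylamino chain, a carboxylic acid at the chain end or a 4-methylpiperazin-1-yl ring would help to do so, while compound 2 differs elsewhere as well and cannot settle the question.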